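Swapping one aromatic ring at the assay limit

A few compounds are considered here, and "the series" means these few. Any claim that something is new, unique, unknown or untested is made for them only; others in the source may bear on it.

Compound 1 `C/C=C/C(=O)Nc1cccc(Oc2nc(Nc3ccc(OC)cc3)nc3c2CSCC3)c1`: > 50000 nM (a limit)
Compound 2 `CC/C=C/C(=O)Nc1cccc(Oc2nc(Nc3ccc(OC)cc3)nc3c2CSCC3)c1`: > 50000 nM (a limit)

Both values come from an ADME assay on L02 cells (Homo sapiens) for cytotoxicity, read by MTT assay, with a stated time of 72 h; a higher number here means a weaker inhibitor, a lower number a stronger inhibitor. Compound 2 has only a limit, > 50000 nM, and no exact number. Compound 1 stands at the same limit: the limit of > 50000 nM in this assay, at which 2 of the 2 values shown sit. Compound 3 `CC/C=C/C(=O)Nc1cccc(Oc2nc(Nc3ccc(OC)nc3)nc3c2CSCC3)c1` has 6-methoxypyridin-3-yl in place of 4-methoxyphenyl on a nitrogen on an aromatic ring. For the measured compounds named here, the one measured step is a step that the two limits leave unreadable from compound 1 to compound 2. It is a different change and gives no size to carry over. With compound 2 at > 50000 nM, again a limit, no step beyond the usual scatter is expected in this assay, and compound 3 will probably also be reported as a limit. The expected step is a number no higher from compound 2 to compound 3 (the limit leaves the size open). Compound 3 is estimated at 50000 nM, with an expected range from 25000 nM to 100000 nM.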

Compound 3, half-maximal inhibitory concentration: > 50000 nM
Compound 3: only a limit was reported; the forecaster's own chance of this, stated with the estimate: 75%; the middle value lies on the limit itself.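

Compound 2 and compound 3 are both reported only as limits in this assay, so no step between them can be read: the limit of > 50000 nM in this assay, at which 3 of the 3 values shown sit.

The compounds shown leave open how far each lies from that limit, and whether 6-methoxypyridin-3-yl in place of 4-methoxyphenyl changes the read-out at all.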